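The compounds below may be only part of what the source reports. "The series", "measured", "known", "first", "only" and "open" are said of these compounds alone.

Measured so far in a functional assay on A549 cells (Homo sapiens) for cytotoxicity, read by MTT assay, with a stated time of 4 days; on this read-out higher numbers stand for weaker inhibition and lower numbers for stronger inhibition:

- compound 1 `C=C1C[C@]23C[C@@]1(O)CC[C@H]2c1ccc(OS(=O)(=O)c2ccc(C)cc2)c(C)c1[C@@H]3Cn1cc(-c2ccc(Cl)cc2)nn1`; in this assay compound 1 gives > 20000 nM, which is a limit of the assay and not a number.
- compound 2 `Cc1ccc(S(=O)(=O)Oc2ccc3c(c2C)[C@H](Cn2cc(-c4ccccc4)nn2)[C@@]24CC(=O)[C@@](C)(CC[C@@H]32)C4)cc1`; in this assay compound 2 gives > 20000 nM, again a limit.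
- compound 3 `Cc1c(O)ccc2c1[C@H](Cn1cc(-c3ccc(F)cc3)nn1)[C@@]13CC(=O)[C@@](C)(CC[C@@H]21)C3`; in this assay compound 3 gives > 20000 nM, also a limit.

Compound 1 therefore stands exactly where the whole measured set stands, at the limit of > 20000 nM in this assay, at which 3 of the 3 values shown sit. For the measured compounds named here, no measured value in this set is a number, so none of the three compounds can be placed above or below another, and no step between measured compounds can be read.

Compound 4 `C=C1C[C@]23C[C@@]1(O)CC[C@H]2c1ccc(OS(=O)(=O)c2ccc(C)cc2)c(C)c1[C@@H]3Cn1cc(-c2ccc(OC)cc2)nn1` is the unmeasured partner of compound 1. The change from compound 1 to compound 4 is methoxy in place of chloro on an aromatic carbon, in words methoxy in place of chloro on an aromatic carbon. Going by the values given here, with no measured step available, the expectation can rest only on the standing of compound 1 at the limit of > 20000 nM in this assay, at which 3 of the 3 values shown sit, which leaves room for a change in either direction without any sign of one. The expected step is a step that the limit leaves unreadable from compound 1 to compound 4, that is, no move beyond the scatter. Compound 4 is estimated at 25000 nM, with a range from 8000 nM to 100000 nM, most likely reported again only as a limit.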

Compound 4, half-maximal inhibitory concentration: > 20000 nM
Compound 4 was reported as a limit; the forecaster's own chance of this, stated with the estimate: 85%; the middle value is on the limit's open side.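

No step can be read between compound 1 and compound 4, with 4-chlorophenyl changed to 4-methoxyphenyl, because both values are limits and not numbers: the limit of > 20000 nM in this assay, at which 4 of the 4 values shown sit.

The compounds shown leave open whether either of these two groups, or any other difference across the series, changes the read-out in this assay.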